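Trimming an ethyl group from a potent binder

The compounds below may be only part of what the source reports. "The series", "measured", "known", "first", "only" and "open" are said of these compounds alone.

Compound 1 `CCc1nc(-c2ccc(Cl)cc2Cl)c(CC)nc1NC(CC)CC` is the strongest of the three measured compounds in an assay on IMR-32 cells for displacement of a labelled ligand from corticotropin-releasing factor receptor 1 (Homo sapiens), read by scintillation counting, with a stated time of 2 h (a higher number here means a weaker inhibitor, a lower number a stronger inhibitor), where compound 1 gives 4.1 nM. Compound 2 `CCc1nc(-c2ccc(Cl)cc2Cl)c(CC)nc1CC(CC)CC` gives 68 nM, a step of a 17-fold higher number from compound 1 to compound 2 (1.22 log units; beyond the scatter). Compound 3 `CCCN(CCN(C)C)c1nc(CC)c(-c2ccc(Cl)cc2Cl)nc1CC` gives 1540 nM, a step of a 380-fold higher number from compound 1 to compound 3 (2.57 log units; beyond the scatter), and the gap between compound 2 and compound 3 is a 23-fold higher number from compound 2 to compound 3 (1.36 log units; beyond the scatter). Both measured steps from compound 1 replace the (pentan-3-yl)amino group, and both weaken binding sharply.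

Compound 4 `CCc1nc(NC(CC)CC)cnc1-c1ccc(Cl)cc1Cl` keeps that group and instead alters the shared core: hydrogen in place of ethyl on an aromatic carbon. For the measured compounds named here, no measured step touches this ethyl, so the earlier steps give no direct guide; they show only that compound 1 sits near the best number seen and that changes elsewhere have cost potency. A small loss is therefore expected, of a 3.7-fold higher number from compound 1 to compound 4 (0.56 log units; beyond the scatter). Compound 4 is expected to give 15 nM, with a range from 4 nM to 60 nM.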

Compound 4, inhibition constant: 545 nM
The estimate for compound 4 lay 36-fold (1.56 log units) below the measured number; the measured number lies above the stated range.
By their numbers in this assay, from the lowest: compound 1; then compound 2; then compound 4; then compound 3.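

In this assay, the step of a 130-fold higher number from compound 1 to compound 4 (2.12 log units; beyond the scatter) shows that this ethyl, ortho to the (pentan-3-yl)amino group, is far from a spare part of the shared core, even though it has only 2 heavy atoms. For the compounds shown here, compounds 1, 2 and 3 all carry this ethyl, so they could show only what happens when the group on the other carbon changes; compound 4 is the first to show that binding also depends strongly on what sits at this position. Nothing available explains why removing the ethyl costs so much.

As far as these compounds go, it remains open whether a methyl group, a longer chain such as propyl, or a methoxy group at this position would restore binding. From the compounds shown here alone, it is also open whether the remaining ethyl, para to this position, matters as much.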